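Swapping One Ring Group in a Series Without Clear Steps

The source may hold more compounds than are shown below. What is called first, only, known or untested is meant among the compounds shown, and "the series" means these compounds.

In a functional assay on HT-1080 cells (Homo sapiens) for cytotoxicity, read by MTT assay, with a stated time of 72 h (on this read-out lower numbers stand for stronger inhibition and higher numbers for weaker inhibition), compound 3 (`COc1ccc(/C=C2\CCC/C(=C\c3ccc(Cl)cc3Cl)C2=O)cc1OC`) gives 10500 nM. Compound 1 (`COc1ccc(/C=C2\CCC/C(=C\c3ccccc3Br)C2=O)cc1OC`) gives 8400 nM and compound 2 (`COc1ccc(/C=C2\CCC/C(=C\c3ccc(O)cc3)C2=O)cc1OC`) gives 16800 nM, so compound 3 lies within the usual scatter of both.

Compound 4 (`COc1cc(/C=C2\CCC/C(=C\c3ccc(OC)c(OC)c3)C2=O)ccc1O`) has not yet been measured. It carries 4-hydroxy-3-methoxyphenyl in place of the 2,4-dichlorophenyl of compound 3, on a double-bonded chain carbon bound to a double-bonded ring carbon: 4-hydroxy-3-methoxyphenyl in place of 2,4-dichlorophenyl on a double-bonded chain carbon bound to a double-bonded ring carbon.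

Three measured steps changed the group at this same place: a 2.0-fold higher number from compound 1 to compound 2 (0.30 log units; within the scatter), a 1.3-fold higher number from compound 1 to compound 3 (0.10 log units; within the scatter) and a 1.6-fold lower number from compound 2 to compound 3 (0.20 log units; within the scatter). All three stayed within the scatter, even when a halogenated group gave way to 4-hydroxyphenyl, the group in compound 2. Within the data shown here, only three compounds support this, so the expectation is modest: no step beyond the scatter in this assay, and no firm direction.

The expected change is a 1.1-fold higher number from compound 3 to compound 4 (0.06 log units; within the scatter). Compound 4 is estimated at 12000 nM, with an expected range of 5000 nM to 26000 nM.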

Compound 4, half-maximal inhibitory concentration: 4600 nM
Compound 4: middle estimate off by 2.6-fold (0.42 log units), on the high side, outside the stated range (below it).
By their numbers in this assay, from the lowest: compounds 4, 1, 3 and 2 (each within the scatter of the next, the first and the last beyond it).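

In this assay this position no longer looks flat: replacing the group here can move the number beyond the scatter, as with the step (a 2.3-fold lower number from compound 3 to compound 4 (0.36 log units; beyond the scatter)) and the larger step (a 3.7-fold lower number from compound 2 to compound 4 (0.56 log units; beyond the scatter)), where methoxy takes the place of hydrogen on an aromatic carbon. The remaining step (a 1.8-fold lower number from compound 1 to compound 4 (0.26 log units; within the scatter)) stays within the scatter, so compound 4 does not separate from compound 1, and the 4-hydroxy-3-methoxyphenyl group cannot be called better than every group seen so far. No available measurement explains these differences.

Only compound 4 carries 4-hydroxy-3-methoxyphenyl at this place, so one result has to stand for that group. Going by these compounds, whether an amine, a carboxylic acid or a longer chain on this aromatic ring would lower the number further remains open.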